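This account rests on a few compounds, and the source may have more. Where it says the series, first, only, none or still open, it means among the compounds named here.

Three compounds share one core and differ only in a group carried on the six-membered ring attached to it. In an assay on isolated protein for binding affinity to corticotropin-releasing factor receptor 1 (Homo sapiens) (on this read-out lower numbers stand for stronger inhibition and higher numbers for weaker inhibition), compound 1 `CCCN(CCC)c1cc(C)nc2c(-c3ncc([N+](=O)[O-])cc3C)c(C)nn12` gives 9.1 nM, compound 2 `CCCN(CCC)c1cc(C)nc2c(-c3ncc(N4CCCCC4)cc3C)c(C)nn12` gives 17 nM, and compound 3 `CCCN(CCC)c1cc(C)nc2c(-c3ncc(N=O)cc3C)c(C)nn12` gives 100 nM. On these numbers compound 3 stands highest, with an 11-fold higher number from compound 1 to compound 3 (1.04 log units; beyond the scatter) and a 5.9-fold higher number from compound 2 to compound 3 (0.77 log units; beyond the scatter), whereas a 1.9-fold higher number from compound 1 to compound 2 (0.27 log units; within the scatter). Compound 4 `CCCN(CCC)c1cc(C)nc2c(-c3ncc(C)cc3N)c(C)nn12` has not yet been measured. Relative to compound 3 the change is a group of 8 heavy atoms (6 carbon, 2 nitrogen; one six-membered aromatic ring with 1 hetero atom) in place of a group of 9 heavy atoms (6 carbon, 2 nitrogen, 1 oxygen; one six-membered aromatic ring with 1 hetero atom), on an aromatic carbon. Within the data shown here, no measured pair makes this exact exchange, so there is no direct guide. The two steps that bear on it both end at compound 3 and both raise the number, one by a large amount and one by a modest amount. Each of the two other groups tried in that position gave a lower number than compound 3, and compound 4 also does away with the group of compound 3, so a move back toward the numbers of compound 1 and compound 2 is expected, though its size is uncertain. For compound 4 the expected step is a 3.3-fold lower number from compound 3 to compound 4 (0.52 log units; beyond the scatter), leading to an estimate of 30 nM with a range from 8 nM to 120 nM.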

Compound 4, inhibition constant: 40 nM
Estimate against measurement, compound 4: 1.3-fold (0.12 log units) below; measured number inside the range.
By their numbers in this assay, from the lowest: compounds 1 and 2 (each within the scatter of the next); then compound 4; then compound 3.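

In this assay the exchange of the whole ring group gives a 2.5-fold lower number from compound 3 to compound 4 (0.40 log units; beyond the scatter) and shows that the number at this place on the core can fall again after the rise seen with compound 3. Unlike the earlier changes, this one alters more than the single group on that ring: 3-amino-5-methylpyridin-2-yl enters with 1 hydrogen-bond donor where the group of compound 3 has 0, yet compound 4 at 40 nM still stands behind both compound 1 at 9.1 nM and compound 2 at 17 nM in the order of numbers. No measurement here gives a reason for the step.

With the ring group changed as a whole, the compounds shown cannot tell how much of the step comes from removing the group of compound 3 and how much from adding the amino group. A ring with the same pattern but with a hydroxyl or methoxy group in place of the amino group, or a ring with an amino group and a longer chain such as ethyl in place of the methyl, would help to separate these parts.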